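Replacing thiophen-3-yl with pyridin-2-yl in compound 3

A few compounds are considered here, and "the series" means these few. Any claim that something is new, unique, unknown or untested is made for them only; others in the source may bear on it.

In a functional assay on HCT-15 cells (Homo sapiens) for cytotoxicity, read by ELISA, with a stated time of 2 days (on this read-out higher numbers stand for weaker inhibition and lower numbers for stronger inhibition), three compounds with a shared core have been measured so far. Compound 1 `Oc1ccc(-c2cc(-c3ccccc3)cc(-c3cccnc3)n2)cc1` gives 15100 nM, compound 2 `Oc1cccc(-c2cc(-c3ccccc3)nc(-c3ccccc3)c2)c1` gives 18000 nM, and compound 3 `Oc1cccc(-c2cc(-c3ccccc3)nc(-c3ccsc3)c2)c1` gives 24600 nM. Compound 3 stands level with the other two: its value lies within the scatter of both, so no order can be read among the three.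

The next compound, compound 4 `Oc1cccc(-c2cc(-c3ccccc3)nc(-c3ccccn3)c2)c1`, differs from compound 3 in one place. It has pyridin-2-yl in place of thiophen-3-yl on an aromatic carbon, next to the ring nitrogen (pyridin-2-yl in place of thiophen-3-yl on an aromatic carbon).

Going by the values given here, one measured step bears directly on this place: a 1.4-fold higher number from compound 2 to compound 3 (0.14 log units; within the scatter), where thiophen-3-yl took the place of phenyl. That exchange of one aromatic group for another stayed within the scatter. Among the compounds with values here, no measured compound carries pyridin-2-yl, so the data offer no direct evidence for this group, and nothing points to a large shift. The expectation therefore rests on the narrow spread of the three values, and it lies close to compound 2 at 18000 nM. The estimated step is a 1.4-fold lower number from compound 3 to compound 4 (0.14 log units; within the scatter), so no change beyond the scatter is expected. For compound 4 the expected value is 18000 nM, with an estimated range of 8000 nM to 35000 nM.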

Compound 4, half-maximal inhibitory concentration: 20900 nM
Compound 4: the middle estimate sits 1.2-fold (0.06 log units) below what was measured; measured number inside the range.
By their numbers in this assay, from the lowest: compounds 1, 2, 4 and 3 (each within the scatter of the next).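

With pyridin-2-yl, this position now carries a third aromatic group, a six-membered ring with a nitrogen as its hetero atom, and in this assay the exchange gives a 1.2-fold lower number from compound 3 to compound 4 (0.07 log units; within the scatter). Set against the phenyl of compound 2, the same group gives a 1.2-fold higher number from compound 2 to compound 4 (0.06 log units; within the scatter), so phenyl, thiophen-3-yl and pyridin-2-yl on this aromatic carbon, next to the ring nitrogen, cannot be told apart on this read-out, whether the ring is five- or six-membered and whether it holds sulfur, nitrogen or no hetero atom at all. No measurement is available that would explain this sameness.

Still open, from the compounds shown here alone, is whether a group other than an aromatic ring at this place, such as an amine, a carboxylic acid or a longer alkyl chain, would give a number outside the scatter of these values. Open too, going by these compounds, is the 3-hydroxyphenyl group, which compounds 2, 3 and 4 all keep, and what would follow if its hydroxyl gave way to a methoxy group or an amine.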